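Ethoxycarbonyl to carbamoyl, starting from compound 1

The source may report more compounds than this note shows. Statements on the series, on what has been measured and on what is new or still open speak of the compounds shown alone.

In a functional assay on HeLa cells (Homo sapiens) (on this read-out higher numbers stand for an effect only at larger amounts of compound and lower numbers for an effect already at smaller amounts), compound 1 (`CCOC(=O)c1cc(CCl)nn1C1O[C@@H](COC(C)=O)[C@H](OC(C)=O)[C@@H](OC(C)=O)[C@@H]1OC(C)=O`) gives 40 ug/mL as the higher of two numbers. Compound 3 (`CCOC(=O)c1cc(CI)nn1C1O[C@@H](COC(C)=O)[C@H](OC(C)=O)[C@@H](OC(C)=O)[C@@H]1OC(C)=O`) gives 2.5 ug/mL as the nearest number. Compound 2 (`CCOC(=O)c1cc(CCl)nn1C1O[C@H](COC(C)=O)[C@@H](OC(C)=O)[C@H](OC(C)=O)[C@H]1OC(C)=O`) reads > 100 ug/mL and this value is a limit. Compound 4 (`CC(=O)OC[C@@H]1OC(n2nc(CCl)cc2C(N)=O)[C@@H](OC(C)=O)[C@H](OC(C)=O)[C@H]1OC(C)=O`) has amino in place of ethoxy on a carbonyl carbon. Neither an at least 2.5-fold higher number from compound 1 to compound 2 (0.39 log units; beyond the scatter) on changing the drawn configuration nor a 16-fold lower number from compound 1 to compound 3 (1.20 log units; beyond the scatter) on iodo in place of chloro involves that carbonyl carbon. These steps show only how far values can move in this series, so no step beyond the scatter is expected in this assay and the range stays wide. The expected step is a 1.3-fold higher number from compound 1 to compound 4 (0.10 log units; within the scatter) for this change. For compound 4 the estimated value is 50 ug/mL with 15 ug/mL to 150 ug/mL as the expected range.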

Compound 4, concentration for half-maximal effect: 18 ug/mL
Compound 4: middle estimate off by 2.8-fold (0.44 log units), on the high side; the measured number falls inside the stated range.
By their numbers in this assay, from the lowest: compound 3; then compound 4; then compound 1. At a limit, above all of these: compound 2.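

In this assay the carbonyl carbon turns out to be a place where the read-out moves: amino in place of ethoxy gives a 2.2-fold lower number from compound 1 to compound 4 (0.35 log units; beyond the scatter). The ethoxy group is therefore not needed for an effect in this pair, and a smaller group with a hydrogen-bond donor is tolerated here. Nothing measured on these compounds gives a reason for this step.

As far as these compounds go, a carboxylic acid or a methylamino group on the same carbonyl carbon remains open. From the compounds shown here alone, it is also open whether amino in place of ethoxy gives a similar step on the iodo compound 3.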